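A few compounds are considered here, and "the series" means these few. Any claim that something is new, unique, unknown or untested is made for them only; others in the source may bear on it.

Compound 1 `CC1(C)[C@H]2CC[C@]1(C)N(Cc1cn(-c3ccccc3Br)nn1)C(=O)C2`: 130 nM
Compound 2 `CC1(C)[C@H]2CC[C@]1(C)N(Cc1cn(-c3ccccc3O)nn1)C(=O)C2`: 230 nM

In a functional assay on A549 cells (Homo sapiens) for inhibition, read by MTT assay, with a stated time of 24 h (on this read-out higher numbers stand for weaker inhibition and lower numbers for stronger inhibition), compound 2 gives 230 nM, which lies within the scatter of compound 1 at 130 nM. Compound 3 `CC1(C)[C@H]2CC[C@]1(C)N(Cc1cn(-c3cccc(O)c3)nn1)C(=O)C2` is the next structure to place, and it has the same atoms as compound 2, joined differently: 3-hydroxyphenyl in place of 2-hydroxyphenyl on an aromatic nitrogen. Among the measured compounds shown here, the only measured step, a 1.8-fold higher number from compound 1 to compound 2 (0.25 log units; within the scatter), is hydroxy in place of bromo on an aromatic carbon, so it bears on this change only indirectly. For the measured compounds named here, no measured pair compares 2-hydroxyphenyl with 3-hydroxyphenyl. The expectation in this assay is therefore no step beyond the scatter, in either direction, and it rests on thin evidence. The expected change is a 1.1-fold higher number from compound 2 to compound 3 (0.04 log units; within the scatter). Compound 3 is estimated at 250 nM, with an expected range from 90 nM to 700 nM.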

Compound 3, half-maximal inhibitory concentration: 180 nM
Compound 3: middle estimate off by 1.4-fold (0.14 log units), on the high side, within the range that was stated.
By their numbers in this assay, from the lowest: compounds 1, 3 and 2 (each within the scatter of the next).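

In this assay, 3-hydroxyphenyl in place of 2-hydroxyphenyl on the aromatic nitrogen gives a 1.3-fold lower number from compound 2 to compound 3 (0.11 log units; within the scatter), so the one comparison of hydroxy placement shown here does not separate the two compounds. 3-Hydroxyphenyl in place of 2-bromophenyl at the same nitrogen gives a 1.4-fold higher number from compound 1 to compound 3 (0.14 log units; within the scatter), which leaves compound 1, compound 2 and compound 3 without a firm order and shows no sensitivity in this assay to any of the three aryl groups compared so far. No supporting measurement bears on this result.

Still open, going by these compounds, is whether unsubstituted phenyl would stay within the scatter of these three compounds. Also open, on these data alone, is whether an amine or a carboxylic acid on the phenyl ring would produce a step beyond the scatter.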